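Replacing the Bromophenyl Amide of Compound 3 with Chloropyridine

The source may report more compounds than this note shows. Statements on the series, on what has been measured and on what is new or still open speak of the compounds shown alone.

Compound 3 `O=C(Nc1ccc2nc(NC(=O)C3CCCCC3)sc2c1)c1ccc(Br)cc1` reaches only the limit of > 4 ug/mL in this assay, at which 1 of the 3 values shown sits, in a functional assay on WI-38 VA13 cells (Homo sapiens) for cytotoxicity; a higher number here means that more compound is needed for the effect, a lower number that less compound is needed; its value is given as > 4 ug/mL, a limit of the measurement rather than a number. Among the measured compounds, compound 1 `N#Cc1cccc(C(=O)Nc2ccc3nc(NC(=O)C4CCCCC4)sc3c2)c1` gives 0.52 ug/mL in this assay, and compound 2 `N#Cc1ccc(C(=O)Nc2ccc3nc(NC(=O)C4CCCCC4)sc3c2)cc1` gives 3.3 ug/mL. The step of an at least 7.6-fold higher number from compound 1 to compound 3 (0.88 log units; beyond the scatter) and the step of an at least 1.2-fold higher number from compound 2 to compound 3 (0.08 log units; that floor lies within the scatter) both lead to compound 3, and the step of a 6.3-fold higher number from compound 1 to compound 2 (0.80 log units; beyond the scatter) shows how strongly the aryl amide portion matters.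

Compound 4 `O=C(Nc1ccc2nc(NC(=O)C3CCCCC3)sc2c1)c1cccnc1Cl` differs from compound 3 by 2-chloropyridin-3-yl in place of 4-bromophenyl on a carbonyl carbon. For the measured compounds named here, no measured pair shows this change, so the expectation rests on the fact that compound 3 sits at the floor and that the other two aryl amides span a modest range. Compound 4 is therefore estimated to show a step of an at least 1.3-fold lower number from compound 3 to compound 4 (0.12 log units; that floor lies within the scatter) in this assay, with a real chance that it, too, returns only a limit. The estimate for compound 4 is 3 ug/mL, within a range of 0.8 ug/mL to 8 ug/mL.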

Compound 4, half-maximal effective concentration: 0.075 ug/mL
The estimate for compound 4 lay 40-fold (1.60 log units) above the measured number; measured number below the stated range.
By their numbers in this assay, from the lowest: compound 4; then compound 1; then compound 2. At a limit, above all of these: compound 3.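

The earlier compounds shown here showed only steps to higher numbers among the substituted phenyl amides, whereas this change on the carbonyl carbon moves the number the other way, even against the best of them, with a 6.9-fold lower number from compound 1 to compound 4 (0.84 log units; beyond the scatter) in this assay. The gain over the para-free naming aside is larger still against the 4-cyanophenyl amide, with a 44-fold lower number from compound 2 to compound 4 (1.64 log units; beyond the scatter), and compound 4 now has the lowest number of the four. Against the 4-bromophenyl amide the change gives an at least 53-fold lower number from compound 3 to compound 4 (1.72 log units; beyond the scatter), but that size is only a floor, as compound 3 stands at a limit of the assay: the limit of > 4 ug/mL in this assay, at which 1 of the 4 values shown sits.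

The ring nitrogen and the chlorine enter together in this one change, so the compounds shown do not tell how much of the drop belongs to each. They also leave open what an amine or a methoxy group in place of the chlorine would do.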